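The source may report more compounds than this note shows. Statements on the series, on what has been measured and on what is new or still open speak of the compounds shown alone.

compound 1 `CC(=O)Nc1cc(=O)n(CC(C)C)c(SCc2ccccc2)n1`: 58500 nM
compound 2 `COc1cc(OC)n2cc(-c3ccc([N+](=O)[O-])cc3)nc2n1`: 70600 nM
compound 3 `COc1cc(OC)n2cc(-c3ccc(N)cc3)nc2n1`: > 100000 nM

All three were tested in a functional assay on LoVo cells (Homo sapiens) for antiproliferative activity, read by MTT assay, with a stated time of 72 h; a lower number here means a stronger inhibitor of growth, a higher number a weaker inhibitor of growth. In this assay compound 3 reaches only (the limit of > 100000 nM in this assay, at which 1 of the 3 values shown sits), a limit of the assay rather than a number, so where it truly stands is not known. Compound 4 `CNc1ccc(-c2cn3c(OC)cc(OC)nc3n2)cc1` differs from compound 3 by methyl in place of hydrogen on a nitrogen on an aromatic ring. Going by the values given here, no measured step matches this exact change; the nearest is an at least 1.4-fold higher number from compound 2 to compound 3 (0.15 log units; that floor lies within the scatter), a step toward weaker growth inhibition whose size is itself uncertain. With only that to go on, the step that the limit leaves unreadable from compound 3 to compound 4 is expected to be small, and compound 4 is expected to give about 150000 nM (range 50000 nM to 500000 nM), quite possibly again reported only as a limit.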

Compound 4, concentration for 50% growth inhibition: > 100000 nM
Compound 4 ended at the assay's limit; the forecaster's own chance of this, stated with the estimate: 60%; the middle value does not contradict the limit.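

In this assay, compound 4, like compound 3, gives only a limit and not a number, so the step between them cannot be read and methyl on this nitrogen brings no readable gain in growth inhibition. Methylamino in place of nitro on the aromatic carbon gives an at least 1.4-fold higher number from compound 2 to compound 4 (0.15 log units; that floor lies within the scatter), so this change is not clearly separated from the nitro starting point either. The limit now holds one more compound: the limit of > 100000 nM in this assay, at which 2 of the 4 values shown sit.

Going by these compounds, it remains open whether an ethyl group or a longer chain on this nitrogen, or a carboxylic acid in place of the nitro group, would give a value below the limit.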